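The source may report more compounds than this note shows. Statements on the series, on what has been measured and on what is new or still open speak of the compounds shown alone.

Measured in a functional assay on the whole organism with Rattus norvegicus as the target; a lower number here means that less compound is needed, a higher number that more compound is needed for the effect:

- Compound 1 `Nc1nc2ccc(OCC(F)(F)F)cc2s1`: 6.5 mg/kg
- Compound 2 `CSCn1c(=N)sc2cc(OC(F)(F)F)ccc21`: 3 mg/kg
- Compound 3 `CCSCCn1/c(=N/C)sc2cc(OC(F)(F)F)ccc21`: 3.7 mg/kg

Compound 3, at 3.7 mg/kg, lies within the usual scatter of both compound 1 and compound 2, so it cannot be told apart from either. Compound 4 `CCSCCn1/c(=N/OC)sc2cc(OC(F)(F)F)ccc21` has methoxy in place of methyl on a double-bonded nitrogen. For the measured compounds named here, no measured pair here shows what this swap does, so the expectation rests on the three close values alone. A slight rise, not beyond the scatter, is expected in this assay. The estimated change is a 1.4-fold higher number from compound 3 to compound 4 (0.13 log units; within the scatter). For compound 4 the estimate is 5 mg/kg, with an expected range from 2 mg/kg to 12 mg/kg.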

Compound 4, dose for half-maximal effect: > 10 mg/kg
Compound 4 was reported as a limit; the forecaster's own chance of this, stated with the estimate: 5%; middle value at least 2.0-fold (0.30 log units) from the limit.
By their numbers in this assay, from the lowest: compounds 2, 3 and 1 (each within the scatter of the next, the first and the last beyond it). At a limit, above all of these: compound 4.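

For the compounds shown here, on the double-bonded nitrogen, methoxy in place of methyl is not a neutral swap: in this assay the change gives an at least 2.7-fold higher number from compound 3 to compound 4 (0.43 log units; beyond the scatter), the first readable step between compounds differing in one place. The entering methoxy adds just one oxygen atom to the methyl it replaces, yet the step lies beyond the scatter. Compound 4 is reported only as a limit, not as a number: the limit of > 10 mg/kg in this assay, at which 1 of the 4 values shown sits.

Going by these compounds, the full size of the step therefore stays unknown. On these data alone, whether an ethyl or a hydroxy group on that nitrogen would behave like methyl or like methoxy also remains open.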